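The source may report more compounds than this note shows. Statements on the series, on what has been measured and on what is new or still open speak of the compounds shown alone.

Compound 3 `Cn1cnc2c(N3CCCCC3)nc(-c3ccccc3Cl)nc21` is the starting point of this account. In an assay on cells for displacement of a labelled ligand from adenosine receptor A1 (Homo sapiens), read by scintillation counting and radioligand binding, with a stated time of 60 min, tested at 10 uM (on this read-out lower numbers stand for less inhibition and higher numbers for more inhibition at the one concentration tested (going by the name of the read-out)), compound 3 gives 35.2%, the higher of the two plain numbers in the set. Its nearest neighbour is compound 2 `Cn1cnc2c(N3CCCCC3)nc(-c3cccc(Cl)c3)nc21`, which in this assay gives 22.4%; the step of a number 12.8 percentage points higher from compound 2 to compound 3 (beyond the scatter) separates the two. Compound 1 `Oc1cccc(-c2nc(N3CCCCC3)c3nc[nH]c3n2)c1` in this assay reaches only a limit of the assay, > 80%, as set out in the limit of > 80% in this assay, at which 1 of the 3 values shown sits.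

The change from compound 3 to compound 4 `Cn1cnc2c(N3CCCCC3)nc(-c3cccc(O)c3O)nc21` is 2,3-dihydroxyphenyl in place of 2-chlorophenyl on an aromatic carbon. Among the measured compounds shown here, the only measured step, a number 12.8 percentage points higher from compound 2 to compound 3 (beyond the scatter), moves a chlorine within the phenyl ring and does not bring in a hydroxyl, so it bears on the present change only indirectly, showing that the phenyl substituent can shift the read-out by a modest amount. For the measured compounds named here, compound 1 carries a hydroxyphenyl group, but it also differs from compound 4 in the methyl on the core, so its result sets no step. The direction of the expectation leans upward, with wide uncertainty.

Compound 4 is estimated to give 50% in this assay, with a likely range from 20% to 85%. The expected step is a number 14.8 percentage points higher from compound 3 to compound 4 (beyond the scatter).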

Compound 4, a percentage reported as inhibition, at one concentration (the size of the read-out at that concentration, not a potency): 17.2%
Beside the measured number, compound 4's estimate is 32.8 percentage points above it; measured number below the stated range.
By their numbers in this assay, from the lowest: compounds 4 and 2 (each within the scatter of the next); then compound 3. At a limit, above all of these: compound 1.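

In this assay, the 2,3-dihydroxyphenyl group on this aromatic carbon between two ring nitrogen atoms gives a number 18 percentage points lower from compound 3 to compound 4 (beyond the scatter), so on this core the two hydroxyl groups of compound 4 do not carry the read-out beyond that of the 2-chlorophenyl group. Set against the 3-chlorophenyl group, the same change gives a number 5.2 percentage points lower from compound 2 to compound 4 (within the scatter), so compound 2 and compound 4 cannot be told apart here, and among the three compounds sharing this core only compound 3 stands clear of the others, by a modest margin. Nothing given here accounts for this pattern in terms of a property of the groups involved.

Compound 1 stands at a limit of the assay and differs from compound 4 in more than one place, so the compounds shown do not separate the part played by the methyl on the core from that of the hydroxyl pattern on the phenyl ring. Also open, as far as these compounds go, is how this core would read with a single hydroxyl on the phenyl ring, or with an amine or a carboxylic acid there in place of the hydroxyl groups.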